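Chloro in place of hydrogen on the core of compound 3

This account rests on a few compounds, and the source may have more. Where it says the series, first, only, none or still open, it means among the compounds named here.

Measured in an assay on microsomes from brain (strain Sprague-Dawley) for inhibition of heme oxygenase 2 (Rattus norvegicus), read by spectrophotometry, with a stated time of 60 min; on this read-out lower numbers stand for stronger inhibition and higher numbers for weaker inhibition:
Compound 1 `Brc1cccc(OCCCCCCn2ccnc2)c1` gives 41000 nM.
Compound 2 `c1ccc2sc(SCCCn3ccnc3)nc2c1` gives 12500 nM.
Compound 3 `c1ccc2sc(SCCCCn3ccnc3)nc2c1` gives 800 nM.

Compound 3 stands lowest of the three numbers: a 16-fold lower number from compound 2 to compound 3 (1.19 log units; beyond the scatter) separates it from compound 2, and compound 1 lies higher still. Compound 4 `Clc1ccc2sc(SCCCCn3ccnc3)nc2c1` differs from compound 3 by chloro in place of hydrogen on an aromatic carbon. Within the data shown here, no measured step touches a substituent on the aromatic ring of this core; the only step, from compound 2 to compound 3, concerns the chain alone and does not bear on the present change. Among the measured compounds shown here, compound 1 carries a bromo on a different core, and no step links it to the others. Compound 4 is therefore expected to give 600 nM (range 200 nM to 2500 nM), a step of a 1.3-fold lower number from compound 3 to compound 4 (0.12 log units; within the scatter) that is expected to stay within the scatter.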

Compound 4, half-maximal inhibitory concentration: 900 nM
Estimate against measurement, compound 4: 1.5-fold (0.18 log units) below; the range from low to high includes it.
By their numbers in this assay, from the lowest: compounds 3 and 4 (each within the scatter of the next); then compound 2; then compound 1.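

In this assay, chloro in place of hydrogen on an aromatic carbon of the shared core gives a 1.1-fold higher number from compound 3 to compound 4 (0.05 log units; within the scatter). Among these compounds, this is the first step on the ring rather than the chain, and it shows that chloro at this carbon, meta to a fused ring and para to a fused ring, leaves the two numbers within the scatter of each other. Nothing measured here accounts for this result. On these data alone, whether an amine or a carboxylic acid at this same carbon would also stay within the scatter remains open, as does whether chloro elsewhere on the ring would.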